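Trading a phenyl for a cyclohexyl on the amine carbon

This account rests on a few compounds, and the source may have more. Where it says the series, first, only, none or still open, it means among the compounds named here.

Measured so far in a functional assay on Ehrlich cells (Mus musculus) for cytotoxicity, read by MTT assay, with a stated time of 24 h; a higher number here means a weaker inhibitor, a lower number a stronger inhibitor:
compound 1, `C[C@H](Nc1nc2cc(Cl)c(F)cc2s1)c1ccccc1`, 36600 nM
compound 2, `CCCCCC[C@@H](C)Nc1nc2cc(Cl)c(F)cc2s1`, 24600 nM

Compound 1 and compound 2 share the same core and differ only in what hangs on the saturated carbon attached to the amine nitrogen. Their two numbers sit close together: the distance between compound 1 and compound 2 lies within the usual scatter of this assay, so the two read as one level rather than as a difference.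

Compound 3, `C[C@H](Nc1nc2cc(Cl)c(F)cc2s1)C1CCCCC1`, keeps everything of compound 1 except one group: cyclohexyl in place of phenyl on a saturated chain carbon bound to a nitrogen on an aromatic ring and a saturated chain carbon. For the measured compounds named here, no measured pair shows this exact change, so there is nothing to copy. What the two measured compounds do show is that a saturated side group, as in compound 2, lands at the same level as the phenyl of compound 1. On that basis the step from compound 1 to compound 3 is expected to be small, a 1.3-fold lower number from compound 1 to compound 3 (0.12 log units; within the scatter), and not clearly beyond the scatter in either direction. Compound 3 is therefore estimated at 28000 nM, with a plausible range from 10000 nM to 80000 nM.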

Compound 3, half-maximal inhibitory concentration: 29800 nM
Compound 3: the middle estimate sits 1.1-fold (0.03 log units) below what was measured; the measured number falls inside the stated range.
By their numbers in this assay, from the lowest: compounds 2, 3 and 1 (each within the scatter of the next).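

In this assay, the swap of phenyl for cyclohexyl gives a 1.2-fold lower number from compound 1 to compound 3 (0.09 log units; within the scatter). For the compounds shown here, this is the first direct comparison of two rings on the saturated chain carbon bound to the amine nitrogen: with the same count of heavy atoms, the aromatic and non-aromatic six-membered carbon rings read as one level here. No independent measurement accounts for this result.

The compounds shown leave open whether a ring carrying an amine or a carboxylic acid on this carbon would give a number clearly outside the scatter. They also do not show whether a much shorter group, such as a methyl, would stay at this same level.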